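Does a longer chain change the antiproliferative value?

The source may hold more compounds than are shown below. What is called first, only, known or untested is meant among the compounds shown, and "the series" means these compounds.

Values in a functional assay on SW480 cells (Homo sapiens) for antiproliferative activity, read by MTT assay, with a stated time of 48 h; a higher number here means a weaker inhibitor, a lower number a stronger inhibitor:
- Compound 1 `CCCCCCCCC(CCO)n1cnc2c(Cl)ncnc21`: 1370 nM
- Compound 2 `CCCCCCCCCC(CCO)n1cnc2c(Cl)ncnc21`: 1150 nM

Compound 2, at 1150 nM, cannot be told apart from compound 1, since their two values lie within the usual scatter of each other. The next analogue is compound 3 `CCCCCCCCCCCC(CCO)n1cnc2c(Cl)ncnc21`, which differs from compound 2 by ethyl in place of hydrogen on a saturated chain carbon, ten or more bonds along the chain from an aromatic nitrogen. Going by the values given here, only one measured step bears on this change, a shorter extension of the same chain: a 1.2-fold lower number from compound 1 to compound 2 (0.08 log units; within the scatter). A single step shows no trend, and the new addition is larger than the methyl of that step, so the range is kept wide. No change beyond the scatter is therefore expected in this assay. The estimate amounts to a 1.2-fold lower number from compound 2 to compound 3 (0.06 log units; within the scatter). For compound 3 the expected value is 1000 nM, with an estimated range of 450 nM to 2200 nM.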

Compound 3, half-maximal inhibitory concentration: 5290 nM
Compound 3: the middle estimate sits 5.3-fold (0.72 log units) below what was measured; the whole stated range lies below it.
By their numbers in this assay, from the lowest: compounds 2 and 1 (each within the scatter of the next); then compound 3.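

In this assay, this chain does not respond evenly to lengthening: the methyl step made no difference that could be told from the scatter, while the ethyl addition moves the number clearly upward (a 4.6-fold higher number from compound 2 to compound 3 (0.66 log units; beyond the scatter)). The same holds when the longest chain is set against the shortest, as propyl in place of hydrogen also gives weaker inhibition (a 3.9-fold higher number from compound 1 to compound 3 (0.59 log units; beyond the scatter)). No measurement in hand accounts for this change in the chain's effect.

Open, as far as these compounds go, is whether the loss sets in gradually or suddenly, which a chain of a length falling between those of compound 2 and compound 3 could show, and whether a still longer chain would weaken inhibition further. An amine or a carboxylic acid at this place could show whether the loss follows size alone or depends on the kind of group.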